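The source may hold more compounds than are shown below. What is called first, only, known or untested is meant among the compounds shown, and "the series" means these compounds.

Measured so far in a functional assay (Homo sapiens) for inhibition; on this read-out higher numbers stand for weaker inhibition and lower numbers for stronger inhibition:
- compound 1 `COc1ccc(/C=C/C(=O)c2ccccc2OC)c(OC)c1`: 26000 nM
- compound 2 `COc1ccc(/C=C/C(=O)c2ccccc2O)c(OC)c1`: 144000 nM
- compound 3 `COc1ccc(OC)c(/C=C/C(=O)c2ccc(O)cc2)c1`: 22000 nM

Of these three, compound 2 has the highest number, which makes it the weakest inhibitor. Compound 4 `COc1ccc(/C=C/C(=O)c2ccc(O)cc2)c(OC)c1` has the same atoms as compound 2, joined differently: 4-hydroxyphenyl in place of 2-hydroxyphenyl on a carbonyl carbon. In words, 4-hydroxyphenyl stands in place of 2-hydroxyphenyl on a carbonyl carbon.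

For the measured compounds named here, only one measured step touches this group: a 5.5-fold higher number from compound 1 to compound 2 (0.74 log units; beyond the scatter), where hydrogen replaces methyl on an oxygen on an aromatic ring. That step is modest but beyond the scatter, and it shows that this assay responds to a change here. Going by the values given here, no measured step tests the swap itself. The closest guide is compound 3, which also carries 4-hydroxyphenyl on its carbonyl carbon and gives 22000 nM, although it differs from compound 4 elsewhere. A clear drop in the number is therefore expected. The expected change is a 5.8-fold lower number from compound 2 to compound 4 (0.76 log units; beyond the scatter). The estimate for compound 4 is 25000 nM, with an expected range of 10000 nM to 60000 nM.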

Compound 4, half-maximal inhibitory concentration: 71000 nM
Compound 4: the middle estimate sits 2.8-fold (0.45 log units) below what was measured, outside the stated range (above it).
By their numbers in this assay, from the lowest: compounds 3 and 1 (each within the scatter of the next); then compound 4; then compound 2.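

Swapping 2-hydroxyphenyl for 4-hydroxyphenyl on the carbonyl carbon gives a 2.0-fold lower number from compound 2 to compound 4 (0.31 log units; beyond the scatter) in this assay and so modestly stronger inhibition, with no atom added or removed. The earlier step changed what sits on an oxygen, whereas this one shows that where the hydroxyl stands on the phenyl ring also counts, even though the two groups have the same heavy atoms and the same hydrogen-bond donor and acceptor counts. No measurement shown here accounts for this difference.

The compounds shown leave open how 3-hydroxyphenyl on the same carbonyl carbon would compare. They also leave open whether an amine or a carboxylic acid in place of the hydroxyl would follow the same order between the two ring positions.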